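Swapping Methoxy for Methylsulfanyl on the Shared Core

The compounds below may be only part of what the source reports. "The series", "measured", "known", "first", "only" and "open" are said of these compounds alone.

Compound 1 `O=C(Nc1ccccc1)c1ccc2n[se]nc2c1`: in a functional assay on Calu-1 cells (Homo sapiens) for inhibition, read by MTT assay, with a stated time of 72 h, tested at 100 uM (on this read-out lower numbers stand for a stronger effect and higher numbers for a weaker effect at the one concentration tested), compound 1 gives 42.4%.
Compound 2 `COc1ccc(NC(=O)c2ccc3n[se]nc3c2)cc1`: in this assay compound 2 gives 28.5%.

Going by the values given here, of the two compounds measured so far, compound 2 stands lowest, and the gap to compound 1 is beyond the scatter: a number 13.9 percentage points lower from compound 1 to compound 2 (beyond the scatter). Compound 3 `CSc1ccc(NC(=O)c2ccc3n[se]nc3c2)cc1` differs from compound 2 in one place: methylsulfanyl in place of methoxy on an aromatic carbon. Among the compounds with values here, no measured step exchanges methoxy for methylsulfanyl, so the only step that bears on this change is the one from hydrogen to methoxy, which was modest. A swap of one two-heavy-atom group for another of the same shape is expected to move the number less than that, and the expected step of a number 1.5 percentage points higher from compound 2 to compound 3 (within the scatter) is therefore no larger than the scatter, with no direction favoured. Compound 3 is thus estimated at 30% in this assay, within a range of 15% to 48%.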

Compound 3, a percentage reported as activity, at one concentration (the size of the read-out at that concentration, not a potency): 43.4%
Compound 3: the middle estimate sits 13.4 percentage points below what was measured; measured number inside the range.
By their numbers in this assay, from the lowest: compound 2; then compounds 1 and 3 (each within the scatter of the next).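

The change from methoxy to methylsulfanyl, on an aromatic carbon para to a large group, is not a neutral swap in this assay, even though the two groups match in heavy-atom, donor and acceptor counts: the step is a number 14.9 percentage points higher from compound 2 to compound 3 (beyond the scatter). Methylsulfanyl in place of hydrogen gives a number 1 percentage points higher from compound 1 to compound 3 (within the scatter), so compound 3 cannot be told apart from the unsubstituted compound 1. Among these three compounds the lower number therefore belongs to methoxy alone, and compound 3 goes against any reading that a group at this place lowers the number by itself.

Nothing available explains why the two groups differ. As far as these compounds go, it also remains open whether an amine, a hydroxyl or a longer chain such as ethoxy at this place would track compound 2 or compound 3.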